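This account rests on a few compounds, and the source may have more. Where it says the series, first, only, none or still open, it means among the compounds named here.

Compound 1 `Cc1ccc(C(=O)Nc2nc(Cl)c3cn(C)nc3n2)cc1` gives > 20000 nM in a functional assay on CHO cells for antagonist activity at adenosine receptor A2b (Homo sapiens), read by 33P incorporation, with a stated time of 20 min, in the presence of a further agent that is not named here (a lower number here means a stronger inhibitor, a higher number a weaker inhibitor), a limit of the assay.
Compound 2 `Cc1ccc(C(=O)Nc2nc(Cl)c3cn(CC(C)(C)C)nc3n2)cc1` gives > 10000 nM in this assay, also a limit.
Compound 3 `Cn1cc2c(Cl)nc(NC(=O)c3ccccc3)nc2n1` gives > 20000 nM in this assay, again a limit.

Compound 3 therefore stands at the limit of > 20000 nM in this assay, at which 2 of the 3 values shown sit, with no number of its own. Compound 4 `CC(C)(C)Cn1cc2c(Cl)nc(NC(=O)c3ccccc3)nc2n1` differs from it by tert-butyl in place of hydrogen on a saturated chain carbon bound to an aromatic nitrogen. Among the compounds with values here, the only measured step of the same kind, a step that the two limits leave unreadable from compound 1 to compound 2, cannot be read: both of its ends are limits. The step that the two limits leave unreadable from compound 1 to compound 3 is unreadable in the same way. Nothing measured here points in either direction. Compound 4 is thus expected to sit at the same limit, estimated at 30000 nM with a range of 10000 nM to 100000 nM. The expected step is a step that the limit leaves unreadable from compound 3 to compound 4, most likely returned by the assay only as a limit.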

Compound 4, inhibition constant: >= 10000 nM
Compound 4: a limit, no number; the forecaster's own chance of this, stated with the estimate: 85%; the middle value does not contradict the limit.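

Compound 4 is returned only as a limit, so neither its step from compound 3 nor its step from compound 2 can be read. The compounds shown leave open how strongly any of them acts in this assay, and whether either change alters this.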